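A Smaller Amide Group Replaces an Aromatic Arm

The source may report more compounds than this note shows. Statements on the series, on what has been measured and on what is new or still open speak of the compounds shown alone.

Compound 1 `COc1ccc2nc(Cl)c(C3CC(c4ccc(C)cc4)=NN3c3nc(-c4ccc(Cl)cc4)cs3)cc2c1` and compound 2 `COc1ccc2nc(Cl)c(C3CC(c4ccc(C)cc4)=NN3c3nc(C)c(/N=N/c4ccccc4)s3)cc2c1` share one core and differ only in the group on the five-membered aromatic ring with 1 nitrogen and 1 sulfur. In a functional assay on HeLa cells (Homo sapiens) for antiproliferative activity (a lower number here means a stronger inhibitor, a higher number a weaker inhibitor), compound 1 gives 38 nM, and compound 2 gives 38 nM, level with compound 1 within the scatter. Compound 3 `CNC(=O)c1sc(N2N=C(c3ccc(C)cc3)CC2c2cc3cc(OC)ccc3nc2Cl)nc1C` takes this position further: a group of 4 heavy atoms (2 carbon, 1 nitrogen, 1 oxygen; no ring) in place of a group of 8 heavy atoms (6 carbon, 2 nitrogen; one six-membered aromatic ring of carbon only), on an aromatic carbon. For the measured compounds named here, no step between measured compounds is known, so the size of this one is open; a modest loss is expected, a 2.6-fold higher number from compound 2 to compound 3 (0.42 log units; beyond the scatter). Compound 3 is estimated at 100 nM, with a range from 25 nM to 400 nM.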

Compound 3, half-maximal inhibitory concentration: 38 nM
Estimate against measurement, compound 3: 2.6-fold (0.42 log units) above, and the stated range covers the measured number.
By their numbers in this assay, from the lowest: compounds 1, 2 and 3 (each within the scatter of the next).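

In this assay the methylcarbamoyl group replaces the phenyl-bearing azo arm with no change at the digits printed from compound 2 to compound 3 (within the scatter), so this aromatic carbon accepts a group without a ring, with the amide hydrogen as a new donor, at an unchanged level. The step with no change at the digits printed from compound 1 to compound 3 (within the scatter) shows that 4-methyl-5-(methylcarbamoyl)-1,3-thiazol-2-yl also matches 4-(4-chlorophenyl)-1,3-thiazol-2-yl on the amine nitrogen in a ring. No measurement at hand accounts for this level. From the compounds shown here alone, whether a carboxylic acid, an amine or a longer chain on the amide nitrogen would hold this level remains open.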